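Compound 2 and the pyrimidin-2-yl step

The source may report more compounds than this note shows. Statements on the series, on what has been measured and on what is new or still open speak of the compounds shown alone.

Compound 1 `Cc1ccc(Nc2nc(-c3ccccn3)cs2)cc1` gives 80000 nM.
Compound 2 `COc1ccc(Nc2nc(-c3cccnc3)cs2)cc1` gives < 10000 nM.

Both entries come from a physicochemical assay for solubility, in phosphate buffer, with a stated time of 2 h, at pH 7.4; a lower number here means a less soluble compound, a higher number a more soluble compound. Compound 1 has a true number there. Compound 2 has only a limit, < 10000 nM, and no number.

Compound 3 `COc1ccc(Nc2nc(-c3ncccn3)cs2)cc1`, not yet measured, differs from compound 2 in one place. It carries pyrimidin-2-yl in place of pyridin-3-yl on an aromatic carbon of a five-membered aromatic ring with 1 nitrogen and 1 sulfur, next to the ring nitrogen. The count of that change is pyrimidin-2-yl in place of pyridin-3-yl on an aromatic carbon.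

Going by the values given here, no two measured compounds differ in just one place, so no step in this assay can be read directly. The expectation rests on compound 2 with its limit < 10000 nM. Only a small rise is expected, one that stays close to the usual scatter, and another limit would be no surprise. The expected change is an at least 1.2-fold higher number from compound 2 to compound 3 (0.07 log units; that floor lies within the scatter). For compound 3 the estimate is 12000 nM, with an expected range from 5000 nM to 40000 nM.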

Compound 3, solubility: 40000 nM
Compound 3: middle estimate off by 3.3-fold (0.52 log units), on the low side; the range from low to high includes it.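

In this assay, pyrimidin-2-yl in place of pyridin-3-yl on an aromatic carbon of the five-membered aromatic ring with 1 nitrogen and 1 sulfur, next to the ring nitrogen, gives an at least 4.0-fold higher number from compound 2 to compound 3 (0.60 log units; beyond the scatter). Going by these compounds alone, this is the first change in one place that can be read, and it shows that the number at this position can move beyond the scatter when one six-membered aromatic ring with 1 hetero atom gives way to one with 2 hetero atoms, with the heavy-atom count unchanged. The true size of the step stays unknown, and only its lower bound is given, because compound 2 has a limit and not a number: the limit of < 10000 nM in this assay, at which 1 of the 3 values shown sits.

Within the data shown here, compound 1 differs from compound 3 in more than one place, so no step involving compound 1 can be read, and whether the change would hold on the core of compound 1 remains open. Going by these compounds, it also remains open how this position would respond to a group of another kind, such as a carboxylic acid or an amine, in place of these six-membered aromatic rings.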